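A few compounds are considered here, and "the series" means these few. Any claim that something is new, unique, unknown or untested is made for them only; others in the source may bear on it.

Of the compounds shown here, three have so far been measured in a functional assay on DU-145 cells (Homo sapiens) for cytotoxicity, read by trypan blue exclusion, with a stated time of 96 h; a lower number here means a stronger inhibitor, a higher number a weaker inhibitor. Compound 1 `COc1ccc(NS(=O)(=O)/C=C/c2c(F)c(F)c(F)c(F)c2F)cc1N` gives 75000 nM, compound 2 `COc1ccc(NS(=O)(=O)/C=C/c2c(OC)cccc2OC)cc1` gives 375 nM, and compound 3 `COc1ccc(NS(=O)(=O)/C=C/c2c(OC)cc(OC)cc2OC)cc1` gives 200 nM. Compound 3 thus holds the lowest of the three numbers, yet compound 2 sits within the scatter of it, so the two cannot be placed in order; only compound 1 stands clearly apart with a far higher number. Among the measured compounds shown here, the single step between measured compounds, a 1.9-fold lower number from compound 2 to compound 3 (0.27 log units; within the scatter), adds a methoxy group and stays within the scatter, so the methoxy pattern on the shared core is the only change for which a size is known.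

Compound 4 `COc1cc(OC)c(/C=C/S(=O)(=O)Nc2ccc(OC)c(NC(C(=O)O)c3ccc(Br)cc3)c2)c(OC)c1` arises from compound 3 by a change of a different kind: ((4-bromophenyl)(carboxy)methyl)amino in place of hydrogen on an aromatic carbon. No measured step introduces such a group at such a place, so nothing shown gives a direct size for it. For the measured compounds named here, compound 1, whose number is 75000 nM, also carries an amino group, but it differs from compound 3 in two places and therefore sets no size for this step either. Going by the values given here, with no precedent, a large entering group is more likely to weaken than to strengthen, so compound 4 is expected to give about 800 nM, within a range from 150 nM to 6000 nM. This estimate corresponds to an expected step of a 4.0-fold higher number from compound 3 to compound 4 (0.60 log units; beyond the scatter), held with considerable uncertainty.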

Compound 4, half-maximal inhibitory concentration: 250 nM
Estimate against measurement, compound 4: 3.2-fold (0.51 log units) above; the measured number falls inside the stated range.
By their numbers in this assay, from the lowest: compounds 3, 4 and 2 (each within the scatter of the next); then compound 1.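

In this assay, placing the ((4-bromophenyl)(carboxy)methyl)amino group on this aromatic carbon, ortho to a methoxy group and meta to a large group, gives a 1.3-fold higher number from compound 3 to compound 4 (0.10 log units; within the scatter). Among the compounds shown here, this is the first size known for any change at this position, and it shows that a group of this bulk, with its own aromatic ring and carboxy group, can take the place of a hydrogen here without a difference that can be told apart from the scatter. Nothing available explains why the number holds at this position.

Because the whole group entered as one change, the compounds shown do not separate what its parts contribute, whether the bromine, the benzene ring or the carboxy group. On these data alone, how the number would read with a methyl ester in place of the carboxylic acid, with chlorine in place of the bromine, or with a plain amino group alone at this position on the shared core remains open.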